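A few compounds are considered here, and "the series" means these few. Any claim that something is new, unique, unknown or untested is made for them only; others in the source may bear on it.

Measured in a functional assay on KBVIN cells (Homo sapiens) for antiproliferative activity, read by sulforhodamine B assay, with a stated time of 3 days; on this read-out lower numbers stand for an effect already at smaller amounts and higher numbers for an effect only at larger amounts of compound:
compound 1 `CCC1=C(O)c2c(oc(-c3ccc(C(F)(F)F)cc3)cc2=O)C(CC)(CC)C1=O`: 10.4 uM
compound 2 `CCC1=C(O)c2c(oc(-c3ccc(OC(F)(F)F)cc3)cc2=O)C(CC)(CC)C1=O`: 9.95 uM
compound 3 `CCC1=C(O)c2c(oc(-c3ccc(CBr)cc3)cc2=O)C(CC)(CC)C1=O`: 27.9 uM

Compound 3 stands highest of the three numbers in this assay. The two steps leading to it, a 2.7-fold higher number from compound 1 to compound 3 (0.43 log units; beyond the scatter) and a 2.8-fold higher number from compound 2 to compound 3 (0.45 log units; beyond the scatter), are both modest and beyond the scatter, whereas a 1.0-fold lower number from compound 1 to compound 2 (0.02 log units; within the scatter) lies within the scatter, so compounds 1 and 2 cannot be told apart on these numbers.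

Compound 4 `CCC1=C(O)c2c(oc(-c3ccc(O)c(C)c3C)cc2=O)C(CC)(CC)C1=O` has not yet been measured. Its difference from compound 3: 4-hydroxy-2,3-dimethylphenyl in place of 4-(bromomethyl)phenyl on an aromatic carbon. Within the data shown here, both measured steps sit at the same aromatic carbon of the shared core, but each exchanges one small group for another; none exchanges the whole phenyl substitution pattern, and no measured compound carries a hydroxy group, methyl groups or any hydrogen-bond donor on that ring. The measured steps therefore bear only loosely on this change: they show that a substituent exchange at this position moves this assay by a modest amount, with bromomethyl giving the highest number. No firm direction can be derived. Compound 4 is expected to fall back toward the range of compounds 1 and 2, estimated at 12 uM with a range of 4 uM to 40 uM. The expected step is a 2.3-fold lower number from compound 3 to compound 4 (0.37 log units; beyond the scatter), which is uncertain and could be none beyond the scatter.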

Compound 4, concentration for half-maximal effect: 2.75 uM
Compound 4: the middle estimate sits 4.4-fold (0.64 log units) above what was measured; the measured number lies below the stated range.
By their numbers in this assay, from the lowest: compound 4; then compounds 2 and 1 (each within the scatter of the next); then compound 3.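

In this assay, among these compounds, the exchange of the whole aryl group on this aromatic carbon, next to the ring oxygen, gives a 10-fold lower number from compound 3 to compound 4 (1.01 log units; beyond the scatter), the only large step at this position; the earlier exchanges were modest or stayed within the scatter. The position therefore allows a much larger change in the number than swapping among trifluoromethyl, trifluoromethoxy and bromomethyl had shown, and the order of the numbers places compound 4 at 2.75 uM ahead of compound 2 at 9.95 uM and compound 1 at 10.4 uM. Nothing in hand accounts for this drop in the number.

In 4-hydroxy-2,3-dimethylphenyl the hydroxy group and the two methyl groups enter together, so the compounds shown do not separate their shares, and that would take a ring carrying only the hydroxy group or only the two methyl groups. Also open, as far as these compounds go, is whether the low number survives when a methoxy group, an amine or a carboxylic acid takes the place of the hydroxy group on that ring.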